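From Methyl to Ethynyl on Compound 2

This account rests on a few compounds, and the source may have more. Where it says the series, first, only, none or still open, it means among the compounds named here.

Of the compounds shown here, three have so far been measured in a physicochemical assay for solubility, read by turbidimetry, measured as kinetic solubility, at pH 7.4 (a higher number here means a more soluble compound, a lower number a less soluble compound), and give the following picture. Compound 2 (`Cc1cccc(N2C(=O)CSC2c2cccc(C(=O)NCCCCc3ccccc3)c2)c1`) gives 10000 nM and stands level with compound 1 (`C#Cc1cc(C(=O)NCCCCc2ccccc2)cc(C2SCC(=O)N2c2ccccc2OC)c1`) at 10000 nM on the numbers shown. Together these two hold the lowest of the three numbers. Compound 3 (`O=C(NCCCCn1cccn1)c1cccc(C2SCC(=O)N2c2ccccn2)c1`) gives 50000 nM and sits higher than both, a gap beyond the usual scatter. Among the measured compounds shown here, no two of these measured compounds differ in only one place, so the data offer no direct precedent for a single change.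

The next step leads from compound 2 to compound 4 (`C#Cc1cccc(N2C(=O)CSC2c2cccc(C(=O)NCCCCc3ccccc3)c2)c1`), which has not yet been measured. The difference is ethynyl in place of methyl on an aromatic carbon and amounts to ethynyl in place of methyl on an aromatic carbon, turning 3-methylphenyl into 3-ethynylphenyl. Compound 1 also carries an ethynyl group, elsewhere in its structure, and its 10000 nM result lies level with compound 2, so no step beyond the scatter is expected here. The estimated step of no change at the digits printed from compound 2 to compound 4 (within the scatter) is therefore expected to show no clear direction. Compound 4 is expected to read about 10000 nM in this assay with an estimated range from 4000 nM to 25000 nM when it is measured.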

Compound 4, solubility: 10000 nM
Compound 4: middle estimate and measured number agree at the digits printed; low and high end bracket the measured number.
By their numbers in this assay, from the lowest: compounds 1, 2 and 4 (each within the scatter of the next); then compound 3.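

In this assay, among the compounds shown here, the swap of methyl for ethynyl on an aromatic carbon of a six-membered aromatic ring of carbon only, meta to a large group, gives no change at the digits printed from compound 2 to compound 4 (within the scatter), and this is the first direct reading of a single change. For the compounds shown here, at this position, 3-methylphenyl and 3-ethynylphenyl therefore cannot be told apart by this read-out, a point the earlier compounds could not settle: compound 1 also carries an ethynyl group, but it differs from the other compounds in more than one place. Nothing available here speaks to the reason for this result.

From the compounds shown here alone, it remains open whether a different group at this position, such as an amine, a carboxylic acid or a longer chain, would shift the reading beyond the scatter, and whether ethynyl in place of methyl would read the same elsewhere on the molecule. Compound 3, at 50000 nM, also differs from compound 2 and compound 4 in more than one place, so its number cannot yet be tied to any single part of its structure.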